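A few compounds are considered here, and "the series" means these few. Any claim that something is new, unique, unknown or untested is made for them only; others in the source may bear on it.

Working notes on the series around a shared core, examined in an ADME assay on Raji cells (Homo sapiens) for cytotoxicity, with a stated time of 72 h; a higher number here means that more compound is needed for the effect, a lower number that less compound is needed. Compound 1 `Cc1cc(NC(=O)Nc2cc(F)ccc2F)c2ccccc2n1` returns only a limit there, > 25000 nM, and no number. Compound 3 `Cc1cc(NC(=O)Nc2ccc(C(=O)O)c(O)c2)c2ccccc2n1` likewise sits at a limit in this assay, > 25000 nM. Going by the values given here, compound 2 `COC(=O)c1ccc(NC(=O)Nc2cc(C)nc3ccccc23)cc1` is the one compound with a measured number in this assay, 17000 nM. Compound 1 stands with the greater part of the values shown, at the limit of > 25000 nM in this assay, at which 2 of the 3 values shown sit. Compound 4 `Cc1cc(NC(=O)Nc2cccc(F)c2)c2ccccc2n1` is the next case; it differs from compound 1 by hydrogen in place of fluoro on an aromatic carbon. Among the compounds with values here, no step between measured compounds is available to size this change. The expectation is for no step beyond the scatter, a step that the limit leaves unreadable from compound 1 to compound 4, so compound 4 would most likely again be reported as a limit. For compound 4 the estimate in this assay is 30000 nM, ranging from 15000 nM to 60000 nM.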

Compound 4, half-maximal effective concentration: > 25000 nM
Compound 4 gave a limit, no number; the forecaster's own chance of this, stated with the estimate: 70%; the middle value is on the limit's open side.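

Compound 1 and compound 4 both return only a limit in this assay, so no step can be read for hydrogen in place of fluoro: the limit of > 25000 nM in this assay, at which 3 of the 4 values shown sit.

The compounds shown leave open whether this change shifts the value at all.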